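The compounds below may be only part of what the source reports. "The series", "measured", "known", "first", "only" and "open" are said of these compounds alone.

- Compound 1 `O=C1C=CC(O)(c2cc3cc(F)ccc3n2S(=O)(=O)c2ccccc2)C=C1` gives 63 nM
- Compound 2 `COc1ccc(S(=O)(=O)n2c(C3(O)C=CC(=O)C=C3)cc3ccccc32)cc1` gives 380 nM

In a functional assay on LOX IMVI cells (Homo sapiens) (on this read-out lower numbers stand for higher toxicity in this test and higher numbers for lower toxicity in this test), compound 1 gives 63 nM and holds the lower of the two numbers, beyond the scatter from compound 2. Compound 3 `COc1ccc2c(c1)cc(C1(O)C=CC(=O)C=C1)n2S(=O)(=O)c1ccccc1` keeps the core of compound 1 but has methoxy in place of fluoro on an aromatic carbon. For the measured compounds named here, no measured pair isolates this change. Compound 2, which carries a methoxy in another place, gives 380 nM as the only hint, so a modest rise in this assay is expected, towards lower toxicity. The expected step is a 2.4-fold higher number from compound 1 to compound 3 (0.38 log units; beyond the scatter) and could still lie within the scatter. For compound 3 the estimate is 150 nM (expected range 50 nM to 450 nM).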

Compound 3, concentration lethal to 50% of the cells: 470 nM
The estimate for compound 3 lay 3.1-fold (0.50 log units) below the measured number; the measured number lies above the stated range.
By their numbers in this assay, from the lowest: compound 1; then compounds 2 and 3 (each within the scatter of the next).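

For the compounds shown here, replacing fluoro with methoxy on this aromatic carbon of the shared core gives the first direct reading of the change: in this assay the number rises, with a 7.5-fold higher number from compound 1 to compound 3 (0.87 log units; beyond the scatter), meaning lower toxicity in this test. At this position, therefore, the choice between these two groups clearly matters. Nothing on hand explains this step.

Going by these compounds alone, compound 2 differs from compound 1 and compound 3 in more than one place, so no step to it can be read. On these data alone, whether a chloro group or an amine at this carbon would behave like fluoro or like methoxy remains open.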